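Rearranging a fluoromethylpyridyl group on a fused core

The compounds below may be only part of what the source reports. "The series", "measured", "known", "first", "only" and "open" are said of these compounds alone.

Compound 2 `Cc1nc(F)ccc1-c1cc2c(cn1)ncn2-c1ccc(OC(F)F)cc1` gives 2000 nM in a functional assay on HL-60 cells (Homo sapiens) for activation, read by flow cytometry, with a stated time of 4 days (on this read-out higher numbers stand for an effect only at larger amounts of compound and lower numbers for an effect already at smaller amounts), the highest of the two numbers recorded so far; its nearest neighbour is compound 1 `Cc1cc(Cl)ccc1-c1cc2c(cn1)ncn2-c1ccc(OC(F)F)cc1`, which in this assay gives 28 nM. Among the measured compounds shown here, the only measured step, a 71-fold higher number from compound 1 to compound 2 (1.85 log units; beyond the scatter), shows that exchanging the group on this aromatic carbon can shift the read-out strongly. Compound 3 `Cc1cc(F)ncc1-c1cc2c(cn1)ncn2-c1ccc(OC(F)F)cc1` differs from compound 2 by a group of 8 heavy atoms (6 carbon, 1 nitrogen, 1 fluorine; one six-membered aromatic ring with 1 hetero atom) in place of a group of 8 heavy atoms (6 carbon, 1 nitrogen, 1 fluorine; one six-membered aromatic ring with 1 hetero atom), on an aromatic carbon. For the measured compounds named here, no measured step describes this kind of rearrangement of the same atoms, so the large effect of a 71-fold higher number from compound 1 to compound 2 (1.85 log units; beyond the scatter) only warns that this position is sensitive, without telling the direction. Compound 3 is therefore expected to give 1000 nM in this assay, within a range of 150 nM to 7000 nM, which amounts to an estimated step of a 2.0-fold lower number from compound 2 to compound 3 (0.30 log units; within the scatter).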

Compound 3, half-maximal effective concentration: 1200 nM
Compound 3: middle estimate off by 1.2-fold (0.08 log units), on the low side; low and high end bracket the measured number.
By their numbers in this assay, from the lowest: compound 1; then compounds 3 and 2 (each within the scatter of the next).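

Rearranging the same atoms within the pyridine group leaves the read-out unresolved: the step (a 1.7-fold lower number from compound 2 to compound 3 (0.22 log units; within the scatter)) does not separate compound 2 from compound 3 in this assay. The large step away from the 4-chloro-2-methylphenyl group recurs with the second arrangement (a 43-fold higher number from compound 1 to compound 3 (1.63 log units; beyond the scatter)), so among the compounds shown it is not tied to a single placement of the ring nitrogen, fluorine and methyl group. No measurement is available that explains this result.

The compounds shown change the ring nitrogen and the halogen together, so they leave open which of the two accounts for the large steps. A 4-fluoro-2-methylphenyl group or a chloro-substituted methylpyridine group would separate these two changes, while an amine on the ring would test a different kind of substituent.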